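Methyl to Methoxy Swap Across Two Cores

The compounds below may be only part of what the source reports. "The series", "measured", "known", "first", "only" and "open" are said of these compounds alone.

Compound 1, `COc1ccccc1Nc1nc(SCc2cn(Cc3ccccc3Cl)nn2)nc(-c2ccccc2)c1C#N`, 5800 nM
Compound 2, `Cc1ccccc1Nc1nc(SCc2cn(Cc3ccccc3Cl)nn2)nc(-c2ccccc2)c1C#N`, 7280 nM
Compound 3, `Cc1ccc(Nc2nc(SCc3cn(Cc4ccccc4Cl)nn3)nc(-c3ccc(C(C)C)cc3)c2C#N)cc1`, > 64000 nM

In a functional assay on MGC-803 cells (Homo sapiens) for inhibition, read by MTT assay, with a stated time of 72 h (a higher number here means a weaker inhibitor, a lower number a stronger inhibitor), compound 2 gives 7280 nM and compound 1 gives 5800 nM. The step methoxy in place of methyl on an aromatic carbon gave a 1.3-fold lower number from compound 2 to compound 1 (0.10 log units; within the scatter). Compound 3, on a different core, reaches only a limit in this assay, > 64000 nM; the difference between the two cores is not broken down here. For compound 3 the value sits at the limit of > 64000 nM in this assay, at which 1 of the 3 values shown sits. Compound 4, `COc1ccc(Nc2nc(SCc3cn(Cc4ccccc4Cl)nn3)nc(-c3ccc(C(C)C)cc3)c2C#N)cc1`, is not yet measured; it carries the same kind of change, (methoxy in place of methyl on an aromatic carbon), but placed para to a large group rather than ortho to a large group. Because compound 3 stands at the limit of > 64000 nM in this assay, at which 1 of the 3 values shown sits, and the earlier step was a 1.3-fold lower number from compound 2 to compound 1 (0.10 log units; within the scatter), compound 4 is expected to stay near that limit. The expected step is a step that the limit leaves unreadable from compound 3 to compound 4. Compound 4 is estimated at 80000 nM, between 20000 nM and 300000 nM.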

Compound 4, half-maximal inhibitory concentration: > 64000 nM
Compound 4 was reported as a limit; the forecaster's own chance of this, stated with the estimate: 70%; the middle value does not contradict the limit.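

Compound 3 and compound 4 both stand at a limit in this assay, so no step can be read between them: the limit of > 64000 nM in this assay, at which 2 of the 4 values shown sit.

The compounds shown leave open whether methoxy in place of methyl shifts the number at all on the core of compound 3.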